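Swapping Trifluoromethyl for Benzyloxy on the Outer Ring

The source may hold more compounds than are shown below. What is called first, only, known or untested is meant among the compounds shown, and "the series" means these compounds.

Compound 1, `COc1ccc(C23CC(C(=O)N[C@H]4C[C@@H](N=C=S)C4)(C2)C3)cc1`: 128 nM
Compound 2, `Fc1cc(-c2cccc(C(F)(F)F)c2)ccc1CO[C@H]1C[C@@H](N=C=S)C1`: 67.2 nM

Of the compounds shown here, two have been measured in an assay on isolated protein for inhibition of N-acylethanolamine-hydrolyzing acid amidase (Homo sapiens), read by fluorescence, with a stated time of 90 min; on this read-out higher numbers stand for weaker inhibition and lower numbers for stronger inhibition. In this assay compound 1 gives 128 nM. In this assay compound 2 gives 67.2 nM. Among the compounds with values here, the two numbers lie within the usual scatter of each other, so neither compound can be called the stronger inhibitor on this evidence; compound 2 simply carries the smaller of the two numbers, and no step between them is established.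

Compound 3, `Fc1cc(-c2cccc(OCc3ccccc3)c2)ccc1CO[C@H]1C[C@@H](N=C=S)C1`, has not yet been measured in this assay. It is built on the same skeleton as compound 2 and differs in one place: benzyloxy in place of trifluoromethyl on an aromatic carbon. In words, a benzyloxy group takes the place of the trifluoromethyl group on an aromatic carbon. No comparable exchange has been measured here, so there is nothing to anchor a direction. The expectation is a modest step from compound 2 to compound 3 of a 1.6-fold higher number from compound 2 to compound 3 (0.21 log units; within the scatter), likely within the scatter. Compound 3 is therefore estimated at 110 nM, with a range from 30 nM to 450 nM.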

Compound 3, half-maximal inhibitory concentration: 99.8 nM
The estimate for compound 3 lay 1.1-fold (0.04 log units) above the measured number; the measured number falls inside the stated range.
By their numbers in this assay, from the lowest: compounds 2, 3 and 1 (each within the scatter of the next).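

In this assay, putting benzyloxy in place of trifluoromethyl on an aromatic carbon, meta to a large group, gives a 1.5-fold higher number from compound 2 to compound 3 (0.17 log units; within the scatter), so compound 2 and compound 3 cannot be told apart. Within the data shown here, this is the first direct comparison at this position, and it shows that a much bulkier substituent can sit there without a step beyond the scatter: benzyloxy brings 8 heavy atoms and a six-membered aromatic ring of carbon only, whereas trifluoromethyl has 4 heavy atoms and no ring. Nothing available explains this result, and the comparison does not show which features of either group matter for inhibition.

On these data alone, with only these two groups to compare, it remains open whether an amine, a carboxylic acid or a longer alkyl chain at this position would give a number clearly apart from those of compound 2 and compound 3. As far as these compounds go, it also remains open whether benzyloxy and trifluoromethyl would compare in the same way on a different core, such as the core of compound 1.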